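One More Carbon on the Five-Membered Ring

The source may report more compounds than this note shows. Statements on the series, on what has been measured and on what is new or still open speak of the compounds shown alone.

Compound 1 `COCCNC(=O)CNc1ncc2c(Br)nn(-c3ccc4ncccc4c3)c2n1` and compound 2 `COCCNC(=O)CCNc1ncc2c(Br)nn(-c3ccc4ncccc4c3)c2n1` carry open-chain amide substituents on the shared core. In an assay on SK-OV-3 cells for inhibition of eIF-2-alpha kinase GCN2 (Homo sapiens) (on this read-out higher numbers stand for weaker inhibition and lower numbers for stronger inhibition), compound 1 is recorded as "nd" (no result reported), and in this assay compound 2 is recorded as "nd" (no result reported), so for neither of them is a result available. Compound 3 `CNC(=O)[C@@H]1CC[C@@H](Nc2ncc3c(Br)nn(-c4ccc5ncccc5c4)c3n2)C1` carries instead a five-membered non-aromatic ring bearing a methyl amide, and in this assay compound 3 gives 25 nM. Among the measured compounds shown here, this is the only measured number in the set, so compound 3 stands alone: no step between measured compounds exists, and nothing can be said about how the ring substituent compares with the open chains of compound 1 and compound 2.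

Compound 4 `CNC(=O)[C@]1(C)CC[C@@H](Nc2ncc3c(Br)nn(-c4ccc5ncccc5c4)c3n2)C1` differs from compound 3 in one place: a group of 10 heavy atoms (8 carbon, 1 nitrogen, 1 oxygen; one five-membered non-aromatic ring of carbon only) in place of a group of 9 heavy atoms (7 carbon, 1 nitrogen, 1 oxygen; one five-membered non-aromatic ring of carbon only), on a nitrogen on an aromatic ring. The substituent grows only slightly, the ring and the amide remaining as they were. For the measured compounds named here, with no measured step to rest on, the expectation for this change relies on its small size alone; such a change is expected to move the inhibitory concentration little, most likely within the usual scatter or toward a modest loss, and the expected step is a 1.4-fold higher number from compound 3 to compound 4 (0.15 log units; within the scatter). Compound 4 is accordingly estimated at 35 nM in this assay, with a range expected from 12 nM to 100 nM.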

Compound 4, half-maximal inhibitory concentration: 21 nM
For compound 4 the middle estimate is 1.7-fold (0.22 log units) above the measured one, within the range that was stated.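

In this assay, the extra carbon in the group on a nitrogen on an aromatic ring gives a 1.2-fold lower number from compound 3 to compound 4 (0.08 log units; within the scatter). Among the compounds shown here, this is the first measured step, and it shows that at this place the group of 10 heavy atoms and the group of 9 heavy atoms, each with its five-membered non-aromatic ring of carbon only and its amide, cannot be told apart on this read-out. No measurement shown here offers an explanation for this result.

The compounds shown leave open how a carboxylic acid or an amine in place of the methyl amide, or a longer chain in place of the added carbon, would read in this assay, and a single step of one carbon says nothing about such larger changes. They also leave open how the opposite arrangement at the two defined stereocentres would compare, and how the ring-bearing groups stand against the open-chain amides of compound 1 and compound 2, for which no number is available.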